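The compounds below may be only part of what the source reports. "The series", "measured", "known", "first", "only" and "open" are said of these compounds alone.

Compound 1 `Clc1ccc(C(c2c[nH]c3ccc(Br)cc23)c2c[nH]c3ccc(Br)cc23)cc1` and compound 2 `Brc1ccc(C(c2c[nH]c3ccc(Br)cc23)c2c[nH]c3ccc(Br)cc23)cc1` are built on the same core and differ in one place only, by the change (bromo in place of chloro on an aromatic carbon). In a functional assay on MCF7 cells (Homo sapiens) for inhibition, read by MTT assay, with a stated time of 48 h (on this read-out higher numbers stand for weaker inhibition and lower numbers for stronger inhibition), compound 1 gives 3500 nM, while compound 2 gives 3200 nM; the step between them is a 1.1-fold lower number from compound 1 to compound 2 (0.04 log units; within the scatter), so the two numbers are not told apart by this measurement. Compound 3 `N#Cc1ccc2[nH]cc(C(c3ccc(Cl)cc3)c3c[nH]c4ccc(C#N)cc34)c2c1` carries a different core; the difference between the two cores is not broken down here. In this assay compound 3 gives 23600 nM, the highest of the three numbers, and its distance from compound 1 and from compound 2 lies beyond the scatter in both cases. Compound 4 `N#Cc1ccc2[nH]cc(C(c3ccc(Br)cc3)c3c[nH]c4ccc(C#N)cc34)c2c1` has not yet been measured. It differs from compound 3 by the change (bromo in place of chloro on an aromatic carbon), the same change, at the same place, that separates compound 2 from compound 1. Since that earlier step was small, the step from compound 3 to compound 4 in this assay is expected to be a 1.1-fold lower number from compound 3 to compound 4 (0.05 log units; within the scatter), an expectation resting on the pair compound 1 and compound 2 and their step of a 1.1-fold lower number from compound 1 to compound 2 (0.04 log units; within the scatter). For compound 4 the value in this assay is therefore estimated at 21000 nM, expected to fall between 10000 nM and 45000 nM.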

Compound 4, half-maximal inhibitory concentration: 27100 nM
For compound 4 the middle estimate is 1.3-fold (0.11 log units) below the measured one, within the range that was stated.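

In this assay the exchange of chloro for bromo on the cyano-bearing core gives a 1.1-fold higher number from compound 3 to compound 4 (0.06 log units; within the scatter), so the two numbers are not told apart by this measurement. Set beside the earlier step on the other core, the change is small in both places, and the two steps do not differ: the same change on two cores in this assay, a 1.1-fold lower number (0.04 log units; within the scatter) from compound 1 to compound 2 and a 1.1-fold higher number (0.06 log units; within the scatter) from compound 3 to compound 4, 1.3-fold (0.10 log units) apart, within the scatter of two such steps. This shows that, for these two pairs, going from 4-chlorophenyl to 4-bromophenyl can be carried from one core to the other without a readable shift in the number, but it does not show that the change would stay as quiet on any further core, and two pairs cannot explain why it is quiet.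

The compounds shown leave open what happens when the group at this place is of another kind altogether, such as an amine, a carboxylic acid or a methoxy group. They also leave open whether the same exchange would remain this small on a core carrying other substituents.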